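Compound 3 gains a methylamino group

The source may hold more compounds than are shown below. What is called first, only, known or untested is meant among the compounds shown, and "the series" means these compounds.

In a physicochemical assay for solubility, read by nephelometry, measured as kinetic solubility, at pH 6.5 (a lower number here means a less soluble compound, a higher number a more soluble compound), compound 3 `Cc1csc(NC(=O)c2cc(C(C)(C)C)nn2Cc2ccccc2)n1` gives < 1.6 ug/mL, which is a limit and not a number. Compound 4 `CNCc1csc(NC(=O)c2cc(C(C)(C)C)nn2Cc2ccccc2)n1` differs from it by one change, methylamino in place of hydrogen on a saturated chain carbon bound to an aromatic carbon, which turns 4-methyl-1,3-thiazol-2-yl into 4-((methylamino)methyl)-1,3-thiazol-2-yl.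

The closest measured comparison is compound 1 `CN(C)Cc1csc(NC(=O)c2cc(C(C)(C)C)nn2Cc2ccccc2)n1`, which carries dimethylamino at that place and gives 25 ug/mL. Hydrogen in place of that dimethylamino produced a large step, an at least 15-fold lower number from compound 1 to compound 3 (1.19 log units; beyond the scatter). Compound 2 `CC(C)(C)c1cc(C(=O)Nc2ccccn2)n(Cc2ccccc2)n1`, with pyridin-2-yl on the amide-type nitrogen, gives 6.3 ug/mL. Its two steps, a 4.0-fold lower number from compound 1 to compound 2 (0.60 log units; beyond the scatter) and an at least 3.9-fold lower number from compound 2 to compound 3 (0.59 log units; beyond the scatter), exchange the whole group and so bear on the change less directly.

Methylamino is one carbon short of dimethylamino, so most of the large step seen with compound 1 is expected to return, in the upward direction. The expected step is an at least 12-fold higher number from compound 3 to compound 4 (1.09 log units; beyond the scatter). For compound 4 the estimate is 20 ug/mL, with an expected range from 7 ug/mL to 50 ug/mL.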

Compound 4, solubility: 12.5 ug/mL
Compound 4: the middle estimate sits 1.6-fold (0.20 log units) above what was measured; the measured number falls inside the stated range.
By their numbers in this assay, from the lowest: compounds 2, 4 and 1 (each within the scatter of the next, the first and the last beyond it). At a limit, below all of these: compound 3.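

In this assay, among the compounds shown here, the saturated chain carbon bound to an aromatic carbon now shows that dimethylamino is not the only group there to carry a higher number than hydrogen, since methylamino does so too (an at least 7.8-fold higher number from compound 3 to compound 4 (0.89 log units; beyond the scatter)). Hydrogen in place of methyl on the amine nitrogen leaves no readable change (a 2.0-fold lower number from compound 1 to compound 4 (0.30 log units; within the scatter)), and the exchange with pyridin-2-yl on the amide-type nitrogen also stays within the scatter (a 2.0-fold higher number from compound 2 to compound 4 (0.30 log units; within the scatter)). The step from hydrogen has only a lower bound, as compound 3 stands at a limit of the assay: the limit of < 1.6 ug/mL in this assay, at which 1 of the 4 values shown sits.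

As far as these compounds go, whether an unsubstituted aminomethyl group or a cyclic amine such as morpholine would sit with compound 1 and compound 4 remains open. So does whether a carboxylic acid or a longer chain bearing the amine at this place would give a similar number.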